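Replacing 4-Methylphenyl with 2-Fluorophenyl in a Vero Cytotoxicity Series

This account rests on a few compounds, and the source may have more. Where it says the series, first, only, none or still open, it means among the compounds named here.

Measured so far in an ADME assay on Vero cells (Chlorocebus sabaeus) for cytotoxicity, read by MTT assay; on this read-out higher numbers stand for weaker inhibition and lower numbers for stronger inhibition:
- compound 1 `C=CCOc1cc(OC)c(C(=O)/C=C/c2ccc(F)cc2)c(OCC=C)c1`: 13600 nM
- compound 2 `C=CCOc1cc(OC)c(C(=O)/C=C/c2ccccc2Br)c(OCC=C)c1`: 13900 nM
- compound 3 `C=CCOc1cc(OC)c(C(=O)/C=C/c2ccc(C)cc2)c(OCC=C)c1`: 211000 nM

Compound 3, at 211000 nM, holds the highest number of the three, and its steps to both other compounds lie beyond the scatter. The next compound to be measured is compound 4 `C=CCOc1cc(OC)c(C(=O)/C=C/c2ccccc2F)c(OCC=C)c1`. It carries 2-fluorophenyl in place of 4-methylphenyl on a double-bonded chain carbon bound to a double-bonded chain carbon.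

Among the compounds with values here, three measured steps bear on this change. Two of them lead to the 4-methylphenyl group and are large: a 16-fold higher number from compound 1 to compound 3 (1.19 log units; beyond the scatter) and a 15-fold higher number from compound 2 to compound 3 (1.18 log units; beyond the scatter). The third links the 4-fluorophenyl and 2-bromophenyl groups and shows no separation: a 1.0-fold higher number from compound 1 to compound 2 (0.01 log units; within the scatter). The 2-fluorophenyl group of compound 4 has not been measured itself, but its name shares features with both of those groups. A large drop in the number is therefore expected, of about the size of those two steps reversed. The estimated step is a 13-fold lower number from compound 3 to compound 4 (1.12 log units; beyond the scatter). With so few compounds, the range stays wide. For compound 4 the expected value in this assay is 16000 nM, with an estimated range from 6000 nM to 60000 nM.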

Compound 4, half-maximal inhibitory concentration: 16300 nM
Compound 4: middle estimate off by 1.0-fold (0.01 log units), on the low side; the range from low to high includes it.
By their numbers in this assay, from the lowest: compounds 1, 2 and 4 (each within the scatter of the next); then compound 3.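

In this assay, the 2-fluorophenyl group returns the series from the isolated value of compound 3, with a 13-fold lower number from compound 3 to compound 4 (1.11 log units; beyond the scatter), so compound 3 now stands apart from three halogen-bearing compounds rather than two. The earlier pair, 4-fluorophenyl and 2-bromophenyl, differed in both the halogen and its place on the ring, whereas compound 4 separates these two changes: exchanging bromo for fluoro on the aromatic carbon gives a 1.2-fold higher number from compound 2 to compound 4 (0.07 log units; within the scatter), and 2-fluorophenyl in place of 4-fluorophenyl gives a 1.2-fold higher number from compound 1 to compound 4 (0.08 log units; within the scatter), so neither change alone separates the compounds. No measurement shown here explains why the 4-methylphenyl compound differs from the other three.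

The compounds shown leave open whether the separation of compound 3 follows the methyl group itself or the absence of a halogen, which a plain phenyl group could help to distinguish. They also do not show whether a methyl group would behave the same way as 2-methylphenyl, or whether a methoxy group in the form of 4-methoxyphenyl would fall with compound 3 or with the halogen-bearing compounds.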